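A few compounds are considered here, and "the series" means these few. Any claim that something is new, unique, unknown or untested is made for them only; others in the source may bear on it.

Measured so far:
compound 1, `NC(=S)N/N=C(/COc1ccc(Br)cc1)c1ccccc1`: < 27500 nM
compound 2, `CC(C)c1ccc(OC/C(=N\NC(N)=S)c2ccc(Br)cc2)cc1`: 24600 nM

Going by the values given here, in an ADME assay on L929 cells (Mus musculus) for cytotoxicity, read by resazurin assay, with a stated time of 96 h (a higher number here means that more compound is tolerated, a lower number that less compound is tolerated), compound 2 gives 24600 nM, the only full number in this small set. For compound 1 the assay reports only a limit, < 27500 nM, which is the limit of < 27500 nM in this assay, at which 1 of the 2 values shown sits. Compound 3, `NC(=S)N/N=C(\COc1ccc(I)cc1)c1ccc(Br)cc1`, is not yet measured. Compared with compound 2, the change is iodo in place of isopropyl on an aromatic carbon. Among the compounds with values here, no measured pair of compounds differs in just one place, so no measured step shows how such a swap moves the reading. The expectation is therefore that the step from compound 2 to compound 3 in this assay stays within the usual scatter, with no clear direction. On that basis compound 3 is estimated at 25000 nM, with a range from 10000 nM to 60000 nM. That estimate means an expected step of a 1.0-fold higher number from compound 2 to compound 3 (0.01 log units; within the scatter), small enough to sit inside the scatter.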

Compound 3, half-maximal cytotoxic concentration: < 20400 nM
Compound 3: only a limit was reported; the forecaster's own chance of this, stated with the estimate: 30%; middle value at least 1.2-fold (0.08 log units) away from the limit.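

Going by these compounds alone, replacing isopropyl with iodo, on an aromatic carbon of a six-membered aromatic ring of carbon only and para to a large group, gives the first step in this set that changes just one place: in this assay, the change gives an at least 1.2-fold lower number from compound 2 to compound 3 (0.08 log units; that floor lies within the scatter). Compound 3 has only a limit, not a number, so this step marks the smallest change the data allow, and the true change may be larger. Within the data shown here, at this position, then, iodo gives no sign that more compound is tolerated than with isopropyl, although the floor alone cannot separate the two groups.

A full number for compound 3 would be needed to show the real size of the step. As far as these compounds go, how an amine, a carboxylic acid or a longer chain at this position would read remains open.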